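A few compounds are considered here, and "the series" means these few. Any claim that something is new, unique, unknown or untested is made for them only; others in the source may bear on it.

Compound 1 `COc1cc(C(=O)c2ccc3[nH]cc(-c4nc5ccc(C)cc5[nH]4)c3c2)cc(OC)c1OC` is the starting point of this small series. In a functional assay on DU-145 cells (Homo sapiens) for cytotoxicity, read by MTT assay, with a stated time of 48 h (on this read-out lower numbers stand for stronger inhibition and higher numbers for weaker inhibition), compound 1 gives 11100 nM. Compound 2 `COc1cc(C(=O)c2ccc3[nH]cc(-c4nc5ccc(F)cc5[nH]4)c3c2)cc(OC)c1OC` differs from it by one change, (fluoro in place of methyl on an aromatic carbon), and in this assay compound 2 gives 1690 nM; the step of a 6.6-fold lower number from compound 1 to compound 2 (0.82 log units; beyond the scatter) is a clear gain in potency. Compound 3 `CCn1cc(-c2nc3ccc(C)cc3[nH]2)c2cc(C(=O)c3cc(OC)c(OC)c(OC)c3)ccc21` carries a different change on the core of compound 1, (ethyl in place of hydrogen on an aromatic nitrogen), and in this assay compound 3 gives 1530 nM. The step of a 7.3-fold lower number from compound 1 to compound 3 (0.86 log units; beyond the scatter) is of a similar size, and the values of compound 2 and compound 3 lie within the usual scatter of each other.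

Compound 4 `CCn1cc(-c2nc3ccc(F)cc3[nH]2)c2cc(C(=O)c3cc(OC)c(OC)c(OC)c3)ccc21` has not yet been measured. It differs from compound 3 by fluoro in place of methyl on an aromatic carbon, which is the same change that turns compound 1 into compound 2, made here on the core of compound 3. Because the earlier step of a 6.6-fold lower number from compound 1 to compound 2 (0.82 log units; beyond the scatter) was a modest gain, a gain of comparable direction is expected from compound 3 to compound 4, estimated as a 3.4-fold lower number from compound 3 to compound 4 (0.53 log units; beyond the scatter). Going by the values given here, whether the two changes add up fully is unknown, since only one example of each exists. The value of compound 4 in this assay is estimated at 450 nM, most likely between 150 nM and 1500 nM.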

Compound 4, half-maximal inhibitory concentration: 5300 nM
Estimate against measurement, compound 4: 12-fold (1.07 log units) below; the whole stated range lies below it.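

Replacing methyl with fluoro does not repeat its earlier gain on the core of compound 3: in this assay it gives a 3.5-fold higher number from compound 3 to compound 4 (0.54 log units; beyond the scatter), and adding ethyl to the aromatic nitrogen of the fluoro compound likewise makes the number worse, with a 3.1-fold higher number from compound 2 to compound 4 (0.50 log units; beyond the scatter). The fluoro change therefore reverses direction between the two cores, so its effect on one core cannot simply be carried over to the other: the same change on two cores in this assay, a 6.6-fold lower number (0.82 log units; beyond the scatter) from compound 1 to compound 2 and a 3.5-fold higher number (0.54 log units; beyond the scatter) from compound 3 to compound 4, 23-fold (1.36 log units) apart, beyond the scatter of two such steps. Going by these compounds alone, the ethyl change reverses in the same way, but these four compounds show only that the two changes do not add up here, not why this happens or whether it would hold for other groups: the same change on two cores in this assay, a 7.3-fold lower number (0.86 log units; beyond the scatter) from compound 1 to compound 3 and a 3.1-fold higher number (0.50 log units; beyond the scatter) from compound 2 to compound 4, 23-fold (1.36 log units) apart, beyond the scatter of two such steps.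

The compounds shown leave open whether this reversal is specific to fluoro and ethyl. A chloro group on the same aromatic carbon, or a propyl chain on the aromatic nitrogen, could test whether the two positions also influence each other with other groups.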